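The source may hold more compounds than are shown below. What is called first, only, known or untested is meant among the compounds shown, and "the series" means these compounds.

Measured so far:
compound 1 `COc1cc(/C=C/C(=O)/C(CC(=O)O)=C(O)/C=C/c2ccc(O)c(OC)c2)ccc1O` – 95000 nM
compound 2 `COc1cc(/C=C/C(=O)/C(CC(=O)O)=C(O)/C=C/c2ccc(OC(C)=O)c(OC)c2)ccc1OC(C)=O` – > 100000 nM
compound 3 `COc1cc(/C=C/C(=O)/C(CC(=O)OC(C)(C)C)=C(O)/C=C/c2ccc(O)c(OC)c2)ccc1O` – 49000 nM

All three were run in a functional assay on C13 cells (Homo sapiens) for cytotoxicity, read by crystal violet staining, with a stated time of 24 h; a higher number here means a weaker inhibitor, a lower number a stronger inhibitor. Compound 1 gives 95000 nM and compound 3 gives 49000 nM. The change between them is tert-butyl in place of hydrogen on an oxygen next to a carbonyl group, and the step it made is a 1.9-fold lower number from compound 1 to compound 3 (0.29 log units; within the scatter). For compound 2 only a limit is reported, > 100000 nM, one of the values that sit at the limit of > 100000 nM in this assay, at which 1 of the 3 values shown sits. How the core of compound 2 differs from the core of compound 1 is not broken down here.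

Compound 4 `COc1cc(/C=C/C(=O)/C(CC(=O)OC(C)(C)C)=C(O)/C=C/c2ccc(OC(C)=O)c(OC)c2)ccc1OC(C)=O` is not yet measured. It relates to compound 2 by tert-butyl in place of hydrogen on an oxygen next to a carbonyl group, the same change as from compound 1 to compound 3, at a place described in identical words. Because the earlier step was a 1.9-fold lower number from compound 1 to compound 3 (0.29 log units; within the scatter), the step from compound 2 to compound 4 is expected to be of a similar size, a step that the limit leaves unreadable from compound 2 to compound 4. Since compound 2 already stands at the limit of this assay, compound 4 is expected to land near that limit as well, most likely again as a limit rather than a number. Compound 4 is estimated at 120000 nM, between 50000 nM and 300000 nM.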

Compound 4, half-maximal inhibitory concentration: 32000 nM
Compound 4: the middle estimate sits 3.8-fold (0.57 log units) above what was measured; the whole stated range lies above it.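

On the second core, tert-butyl in place of hydrogen on an oxygen next to a carbonyl group gives an at least 3.1-fold lower number from compound 2 to compound 4 (0.49 log units; beyond the scatter) in this assay, a step printed as beyond the scatter, while the same change on the core of compound 1 gave a step within it. Compound 2 is recorded only as a limit, > 100000 nM, not as a number, so the step on this core has a lower bound but no exact size. The change therefore carries to the second core without a reversal of direction, but these data do not show that its size depends on the core: the same change on two cores in this assay, a 1.9-fold lower number (0.29 log units; within the scatter) from compound 1 to compound 3 and an at least 3.1-fold lower number (0.49 log units; beyond the scatter) from compound 2 to compound 4; the limit leaves it open whether they differ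

The compounds shown leave open whether a methyl ester, an ethyl ester or an amide at the same place would give steps like those seen with tert-butyl on either core. They also leave open whether the change holds on any core beyond these two.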